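The compounds below may be only part of what the source reports. "The series", "measured", "known", "first", "only" and "open" are said of these compounds alone.

The compounds measured so far in a functional assay on P388 cells (Mus musculus) for cytotoxicity; on this read-out lower numbers stand for an effect already at smaller amounts and higher numbers for an effect only at larger amounts of compound:

Compound 1, `CCC[C@@H](OC(C)=O)C1=C(Br)C(=C(Br)Br)OC1=O`: "not determined" (no result reported)
Compound 2, `CCCCCCC(=O)C(Br)=C(Br)Br`: > 5 ug/mL, a limit of the assay
Compound 3, `CCC[C@@H](OC(C)=O)C1=C(Br)[C@@](OC)(C(Br)Br)OC1=O`: "not determined" (no result reported)

Compound 1 stands without a single number in this assay; its entry reads "not determined" (no result reported). Compound 3 also has no number in this assay, shown as "not determined" (no result reported). Compound 2 gives only a limit in this assay, > 5 ug/mL, which marks the edge of what the assay reports rather than a measured number, as described by the limit of > 5 ug/mL in this assay, at which 1 of the 3 values shown sits. Among the measured compounds shown here, no measured step between two compounds is therefore available, and nothing can yet be said about how one change moves the read-out.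

Compound 4, `CCCCC1=C(Br)C(=C(Br)Br)OC1=O`, differs from compound 1 in one place: hydrogen in place of acetoxy on a saturated chain carbon bound to a double-bonded ring carbon and a saturated chain carbon. For the measured compounds named here, with no step measured, the size and direction of the change in this assay cannot be read from the data; a step within the usual scatter is as plausible as one beyond it, in either direction. Compound 4 is expected to give about 5 ug/mL in this assay, with a likely range from 1 ug/mL to 25 ug/mL, and a real chance that only a limit is reported.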

Compound 4, concentration for half-maximal effect: > 5 ug/mL
Compound 4: only a limit was reported (the forecaster's own chance of this, stated with the estimate: 40%); the middle value sits exactly at the limit.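

Among the compounds shown here, compound 1 has no number in this assay and compound 4 gives only a limit, so no step between them can be read. The compounds shown leave open whether replacing acetoxy with hydrogen changes the read-out at all, and what their actual values are: the limit of > 5 ug/mL in this assay, at which 2 of the 4 values shown sit.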